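The source may hold more compounds than are shown below. What is called first, only, known or untested is meant among the compounds shown, and "the series" means these compounds.

Measured so far:
Compound 1, `CC1=CC[C@H]2[C@@H]1CC=C(C)[C@@H](CC[C@H]1[C@]3(C)CC[C@H](O)C(C)(C)O[C@H]3CC[C@@]1(C)O)C2(C)C`: > 50000 nM
Compound 2, `CC1=CC[C@H]2[C@H](CC[C@]2(C)O)C(C)(C)[C@@H]1CC[C@H]1[C@]2(C)CC[C@H](OC(=O)NS(=O)(=O)c3ccc(C)cc3)C(C)(C)O[C@H]2CC[C@@]1(C)O`: 47100 nM

Of the compounds shown here, two have been tested in a functional assay on MDA-MB-231 cells (Homo sapiens) for antiproliferative activity, read by MTT assay, with a stated time of 72 h; a higher number here means a weaker inhibitor, a lower number a stronger inhibitor. For compound 1 the result is only a limit, > 50000 nM, and no number stands behind it. Among the measured compounds shown here, compound 2 gives 47100 nM in this assay, and this is the only number in the set. The result for compound 1 is the limit (the limit of > 50000 nM in this assay, at which 1 of the 2 values shown sits). For the measured compounds named here, compound 2 therefore stands alone as the one compound with a measured value, and that value lies close to the edge of what the assay resolves.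

Compound 3, `CC1=CC[C@H]2[C@H](CC[C@]2(C)O)C(C)(C)[C@@H]1CC[C@H]1[C@]2(C)CC[C@H](OC(=O)c3ccc(C(F)(F)F)c(F)c3)C(C)(C)O[C@H]2CC[C@@]1(C)O`, has not yet been tested. It differs from compound 2 in one place: 3-fluoro-4-(trifluoromethyl)phenyl in place of ((4-methylphenyl)sulfonyl)amino on a carbonyl carbon. Going by the values given here, no step between two measured compounds is available, so the size of this change cannot be read from the set itself. The writer expects the step from compound 2 to compound 3 to be a 1.6-fold lower number from compound 2 to compound 3 (0.20 log units; within the scatter), a small move toward stronger inhibition that may well remain within the scatter. For compound 3 the expected result in this assay is 30000 nM, with a range from 8000 nM to 100000 nM.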

Compound 3, half-maximal inhibitory concentration: 22200 nM
Compound 3: middle estimate off by 1.4-fold (0.13 log units), on the high side; measured number inside the range.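

In this assay, among the compounds shown here, putting 3-fluoro-4-(trifluoromethyl)phenyl in place of ((4-methylphenyl)sulfonyl)amino on a carbonyl carbon gives a 2.1-fold lower number from compound 2 to compound 3 (0.33 log units; beyond the scatter), the first step in the set that can be read, and it shows that the number at this position responds to the group placed there, though only modestly. The exchange keeps the count of heavy atoms and the aromatic ring but removes the hydrogen-bond donor and acceptors of the leaving group, and compound 3 still gives a measured 22200 nM, so these features of ((4-methylphenyl)sulfonyl)amino are not required for a measurable result in this pair. Compound 1 adds no number to this comparison, as its result is a limit only: the limit of > 50000 nM in this assay, at which 1 of the 3 values shown sits.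

The step changes the link to the carbonyl carbon and the substituents on the ring together, so the compounds shown leave open which part of the exchange accounts for it. They also leave open how an unsubstituted phenyl, an amine or a carboxylic acid on the same carbonyl carbon would read in this assay.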